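This account rests on a few compounds, and the source may have more. Where it says the series, first, only, none or still open, it means among the compounds named here.

Measured so far in a functional assay on CRL2813 cells (Homo sapiens) for cytotoxicity, read by sulforhodamine B assay, with a stated time of 5 days; a higher number here means a weaker inhibitor, a lower number a stronger inhibitor:

Compound 1, `O=C(Nc1cccc(C(F)(F)F)c1)N[C@H]1CC[C@H](Oc2ccc(Cl)cc2)CC1`, gives 2000 nM.
Compound 2, `O=C(Nc1cccc(F)c1)N[C@H]1CC[C@H](Oc2ccc(F)cc2)CC1`, gives 8300 nM.
Compound 3, `O=C(Nc1cccc(C(F)(F)F)c1)N[C@H]1CC[C@@H](Oc2ccc(F)cc2)CC1`, gives 2600 nM.

Compound 2 stands at the highest number of the three, with compound 3 nearest and compound 1 furthest, both gaps beyond the scatter of this assay. Compound 4, `O=C(Nc1ccccc1I)N[C@H]1CC[C@H](Oc2ccc(F)cc2)CC1`, is not yet measured. It differs from compound 2 in one place: 2-iodophenyl in place of 3-fluorophenyl on an amide-type nitrogen. Among the compounds with values here, no step between two measured compounds matches this change, so its size is uncertain. Compound 2 has the weakest value shown, and both other compounds carry something other than a 3-fluorophenyl there, so a modest move toward lower numbers is expected, a 2.1-fold lower number from compound 2 to compound 4 (0.32 log units; beyond the scatter). Compound 4 is estimated at 4000 nM, within 1500 nM to 12000 nM.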

Compound 4, half-maximal inhibitory concentration: > 20000 nM
Compound 4: a limit, no number; the forecaster's own chance of this, stated with the estimate: 5%; at least 5.0-fold (0.69 log units) between middle value and limit.
By their numbers in this assay, from the lowest: compounds 1 and 3 (each within the scatter of the next); then compound 2. At a limit, above all of these: compound 4.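

Compound 4 gives > 20000 nM in this assay, which is a limit of the assay and not a number. Even so, placing 2-iodophenyl instead of 3-fluorophenyl on the amide-type nitrogen gives an at least 2.4-fold higher number from compound 2 to compound 4 (0.38 log units; beyond the scatter), showing that a change at this position can also make a compound weaker. The full size of this step cannot be read: the limit of > 20000 nM in this assay, at which 1 of the 4 values shown sits.

The 2-iodophenyl and 3-fluorophenyl groups differ in both the halogen and where it sits, and the compounds shown do not separate these two changes. Also open, going by these compounds, is how a plain phenyl, or a phenyl carrying an amine or a carboxylic acid, would behave here.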